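The source may hold more compounds than are shown below. What is called first, only, known or untested is meant among the compounds shown, and "the series" means these compounds.

In a functional assay on HT-29 cells (Homo sapiens) for antiproliferative activity, read by sulforhodamine B assay, with a stated time of 48 h (on this read-out higher numbers stand for weaker inhibition and lower numbers for stronger inhibition), compound 2 `O=C1NCCN1c1ccc(S(=O)(=O)Nc2ccc(F)cc2)cc1` gives 370 nM. This is the only numerical value on the read-out so far; the other result shown is a limit. Compound 1 `O=C1NCCN1c1ccc(S(=O)(=O)Nc2ccc(C3CCCCC3)cc2)cc1` gives only a limit, > 1000 nM, in this assay. Among the measured compounds shown here, the single step between measured compounds, an at least 2.7-fold lower number from compound 1 to compound 2 (0.43 log units; beyond the scatter), is therefore known only as a bound because compound 1 sits at the limit of > 1000 nM in this assay, at which 1 of the 2 values shown sits.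

Compound 3 `O=C1NCCN1c1ccc(S(=O)(=O)Nc2cccc(Br)c2)cc1` has not yet been measured. Relative to compound 2 it carries 3-bromophenyl in place of 4-fluorophenyl on a sulfonamide nitrogen. For the measured compounds named here, the one measured step, an at least 2.7-fold lower number from compound 1 to compound 2 (0.43 log units; beyond the scatter), concerns an exchange of the group on the ring attached to the sulfonamide nitrogen and shows that this group can shift the number by a modest amount or more, but it covers neither 3-bromophenyl nor 4-fluorophenyl against each other, so its size cannot be transferred directly. For compound 3 the expected step is a 1.8-fold higher number from compound 2 to compound 3 (0.24 log units; within the scatter), a modest move towards a weaker number that may or may not clear the scatter. The estimate for compound 3 in this assay is 650 nM, within a range from 200 nM to 2500 nM.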

Compound 3, half-maximal inhibitory concentration: 77 nM
For compound 3 the middle estimate is 8.4-fold (0.93 log units) above the measured one, and the stated range ends above it.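

In this assay, the group on a sulfonamide nitrogen now has a step with a number at both ends: 3-bromophenyl in place of 4-fluorophenyl gives a 4.8-fold lower number from compound 2 to compound 3 (0.68 log units; beyond the scatter) and so moves the read-out beyond the scatter, whereas the earlier step at this place rested on a limit. Both groups count 7 heavy atoms, one six-membered aromatic ring of carbon only, 0 hydrogen-bond donors and 0 hydrogen-bond acceptors, so a step of this size at this place does not depend on a change in any of those counts. Among the compounds shown here, nothing measured so far bears on the cause of this step.

The exchange alters the halogen and its place on the ring together, and the compounds shown leave open which of the two carries the step, a question that 4-bromophenyl and 3-fluorophenyl would separate. Also open, as far as these compounds go, is whether the gain is tied to a halogen at all, or whether 3-methoxyphenyl, 3-aminophenyl or a phenyl ring bearing a carboxylic acid at that place would hold the same number.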